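The source may report more compounds than this note shows. Statements on the series, on what has been measured and on what is new or still open speak of the compounds shown alone.

For the measured compounds named here, only two compounds have so far been measured in a functional assay on U-251 cells (Homo sapiens) for inhibition, read by sulforhodamine B assay, with a stated time of 48 h (a higher number here means a weaker inhibitor of growth, a lower number a stronger inhibitor of growth), and they give little to go on. Compound 1 (`COc1cc(-c2nn(-c3cccc(NC(=O)c4cccc(C(F)(F)F)c4)c3)cc2-c2ccncc2)ccc1Cl`) gives 1620 nM while compound 2 (`O=C(Nc1cccc(-n2cc(-c3ccncc3)c(-c3ccc(Cl)c(O)c3)n2)c1)Nc1cc(C(F)(F)F)cc(C(F)(F)F)c1`) gives 463 nM and so compound 1 holds the higher of the two numbers, by a gap beyond the usual scatter. Compound 3 (`COc1cc(-c2nn(-c3cccc(NC(=O)c4ccccc4)c3)cc2-c2ccncc2)ccc1Cl`) is still unmeasured and differs from compound 1 in one place (hydrogen in place of trifluoromethyl on an aromatic carbon): hydrogen stands in place of trifluoromethyl on an aromatic carbon, meta to a large group, so that 3-(trifluoromethyl)phenyl becomes phenyl. Going by the values given here, no measured pair shows this change on its own, and both measured compounds carry trifluoromethyl. A moderate step is therefore expected in this assay toward a higher number, meaning weaker inhibition of growth, although a step within the scatter cannot be ruled out. The estimate amounts to a 1.9-fold higher number from compound 1 to compound 3 (0.27 log units; within the scatter) and remains tentative. For compound 3 the estimated value is 3000 nM with 1200 nM to 8000 nM as the expected range.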

Compound 3, concentration for 50% growth inhibition: 661 nM
Compound 3: the middle estimate sits 4.5-fold (0.66 log units) above what was measured; measured number below the stated range.
By their numbers in this assay, from the lowest: compounds 2 and 3 (each within the scatter of the next); then compound 1.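

The change from 3-(trifluoromethyl)phenyl to phenyl, with hydrogen in place of trifluoromethyl on an aromatic carbon, meta to a large group, gives a 2.5-fold lower number from compound 1 to compound 3 (0.39 log units; beyond the scatter) in this assay. For the compounds shown here, this is the first step here that isolates a single change, and the earlier compounds could not show it, as both carry trifluoromethyl. In this pair, trifluoromethyl at this position is not needed for growth inhibition, and the compound with hydrogen there is the stronger inhibitor of growth; nothing available explains the direction of this step.

The compounds shown leave open whether this result is particular to trifluoromethyl or extends to other groups at this position, such as chlorine, methoxy or an amine, as this pair speaks only for hydrogen against trifluoromethyl. They also leave open whether the same change would give a similar step in the setting of compound 2, which differs from compound 1 in more than one place.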